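The source may hold more compounds than are shown below. What is called first, only, known or untested is meant among the compounds shown, and "the series" means these compounds.

Two compounds of this series carry numbers in a functional assay on blood for antagonist activity at thromboxane A2 receptor (Homo sapiens); a lower number here means tighter binding, a higher number weaker binding. Compound 1 `O=C(O)CC/C=C\CO[C@H]1C(OCc2ccc(-c3ccccc3)cc2)CC[C@@H]1N1CCCCCC1` gives 12.6 nM. Compound 2 `O=C(O)CC/C=C\CO[C@H]1[C@@H](OCc2ccc(-c3ccccc3CO)cc2)CC[C@@H]1N1CCCCCC1` gives 1.59 nM, the lower of the two numbers, and the gap to compound 1 lies beyond the scatter. Compound 3 `O=C(O)CC/C=C\CO[C@H]1[C@H](OCc2ccc(-c3ccccc3CO)cc2)CC[C@@H]1N1CCCCCC1` is the next step from compound 2: the two compounds have the same atoms and bonds and differ only in configuration as drawn: 1 of 4 stereo elements differ; a stereocentre at a saturated ring carbon is drawn S in compound 2 and R in compound 3. Going by the values given here, no step between measured compounds covers such an inversion, so its size rests on expectation alone; a weakening beyond the scatter is expected. The expected step is a 19-fold higher number from compound 2 to compound 3 (1.28 log units; beyond the scatter). For compound 3 the estimate in this assay is 30 nM, within 5 nM to 200 nM.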

Compound 3, dissociation constant: 6.31 nM
The estimate for compound 3 lay 4.8-fold (0.68 log units) above the measured number; the measured number falls inside the stated range.
By their numbers in this assay, from the lowest: compound 2; then compounds 3 and 1 (each within the scatter of the next).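

In this assay, inverting the stereocentre at this saturated ring carbon from S to R gives a 4.0-fold higher number from compound 2 to compound 3 (0.60 log units; beyond the scatter), a modest step. Nothing else changes, so the step can be assigned to configuration at this centre alone: the fact that compounds 2 and 3 differ only in the configuration as drawn. Going by these compounds alone, no earlier pair isolated this stereocentre, and compound 3, with the R configuration, still gives 6.31 nM.

The compounds shown leave open whether the step keeps its size with a methoxymethyl or carboxamide group in place of the hydroxymethyl group. As far as these compounds go, the contribution of the other stereo elements also remains open.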